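The compounds below may be only part of what the source reports. "The series", "measured", "known", "first", "only" and "open" are said of these compounds alone.

Of the compounds shown here, three built on one shared core have been tested in a functional assay on Ishikawa cells (Homo sapiens) for inhibition, read by MTT assay, with a stated time of 72 h, tested at 30 ug/mL; a lower number here means less inhibition of growth, a higher number more inhibition of growth at the concentration tested. Compound 2 `C=C1[C@H](OCC(C)C)CC(=O)C(C)(C)/C=C/[C@@H](C)C(=O)[C@@]2(OC(C)=O)C[C@H](C)[C@H](OC(C)=O)[C@@H]2[C@H]1OC(C)=O` gives 98.4% in this assay. Compound 3 `C=C1[C@H](OC(C)=O)CC(=O)C(C)(C)/C=C/[C@@H](C)C(=O)[C@@]2(OC(C)=O)C[C@@](C)(OC(=O)c3ccccc3)[C@H](OC(C)=O)[C@@H]2[C@H]1OC(C)=O` gives 29.4%, the second highest of the three numbers, while compound 1 `C=C1[C@H](OCC(C)C)[C@@H](OC(C)=O)[C@@H](OC(C)=O)C(C)(C)[C@@H]2O[C@](O)([C@H](C)[C@@H]2OC(C)=O)[C@@]2(OC(C)=O)C[C@@](C)(OC(C)=O)[C@H](OC(C)=O)[C@@H]2[C@H]1OC(C)=O` gives 17.7%. The gap from compound 1 up to compound 3 and the gap from compound 3 up to compound 2 both lie beyond the scatter of this assay. Compound 4 `C=C1[C@H](OC(C)=O)CC(=O)C(C)(C)/C=C/[C@@H](C)C(=O)[C@@]2(OC(C)=O)C[C@@](C)(OC(C)=O)[C@H](OC(C)=O)[C@@H]2[C@H]1OC(C)=O` has not yet been measured. It differs from compound 3 in a single place: methyl in place of phenyl on a carbonyl carbon. Among the measured compounds shown here, no measured pair shows this same change, so nothing is known here about the size of such a step. The expected step of a number 10.6 percentage points higher from compound 3 to compound 4 (beyond the scatter) points modestly upward, with wide uncertainty. Compound 4 is estimated at 40%, between 15% and 75%.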

Compound 4, percent growth inhibition at one concentration: 35%
For compound 4 the middle estimate is 5 percentage points above the measured one; measured number inside the range.
By their numbers in this assay, from the lowest: compound 1; then compounds 3 and 4 (each within the scatter of the next); then compound 2.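

In this assay the change from benzoyloxy to acetoxy is a number 5.6 percentage points higher from compound 3 to compound 4 (within the scatter) at this position. The six-carbon aromatic ring can therefore give way to a single methyl on this carbonyl carbon with no difference that this assay can separate from its usual scatter. Nothing available here offers an explanation for this result.

Still open, going by these compounds, is whether a longer chain such as butyl, or an amine, on this carbonyl carbon would also leave the reading unchanged. Also open, on these data alone, is what a free hydroxyl in place of the whole ester would do.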